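This account rests on a few compounds, and the source may have more. Where it says the series, first, only, none or still open, it means among the compounds named here.

Measured compounds:

Compound 1 `Nc1c(C2=NCCN2)cnn1-c1ccc(F)cc1`. In an ADME assay on Vero cells (Chlorocebus sabaeus) for cytotoxicity, read by CellTiter-Glo and ATP content, with a stated time of 72 h (a higher number here means that more compound is tolerated, a lower number that less compound is tolerated), compound 1 gives > 500000 nM, which is a limit of the assay and not a number.
Compound 2 `Nc1c(C2=NCCN2)cnn1-c1ccc(Br)cc1`. In this assay compound 2 gives > 500000 nM, again a limit of the assay.
Compound 3 `Nc1c(C2=NCCCN2)cnn1-c1ccc(F)cc1`. In this assay compound 3 gives > 500000 nM, likewise a limit of the assay.

The unmeasured member of the set is compound 4 `Nc1c(C2=NCCCN2)cnn1-c1ccc(Br)cc1`.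

From compound 1 to compound 2 the change is bromo in place of fluoro on an aromatic carbon. The step in this assay for this pair is a step that the two limits leave unreadable from compound 1 to compound 2, so no size can be read from it. The cores of compound 1 and compound 3 differ as follows: a group of 6 heavy atoms (4 carbon, 2 nitrogen; one six-membered non-aromatic ring with 2 hetero atoms) in place of a group of 5 heavy atoms (3 carbon, 2 nitrogen; one five-membered non-aromatic ring with 2 hetero atoms), on an aromatic carbon. The corresponding step is a step that the two limits leave unreadable from compound 1 to compound 3, and again the size is not readable. What holds all three results together is the limit of > 500000 nM in this assay, at which 3 of the 3 values shown sit.

From compound 3 to compound 4 the change is bromo in place of fluoro on an aromatic carbon. The two place descriptions match word for word, so this is the same change as that from compound 1 to compound 2. Going by the values given here, no measured step in this set resolves into a number, and for the halogen change the step in this assay is expected to be a number no higher from compound 3 to compound 4 (the limit leaves the size open), resting on the fact that compound 2 gives > 500000 nM in this assay and that the parent compound 3 sits at the same limit. Compound 4 is therefore estimated to give 500000 nM in this assay, with an expected range from 200000 nM to 1000000 nM, most probably reported once more only as a limit.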

Compound 4, half-maximal cytotoxic concentration: > 500000 nM
Compound 4: no number, only a limit (the forecaster's own chance of this, stated with the estimate: 85%); the middle value sits exactly at the limit.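

No new step can be read for compound 4 against compound 3 or compound 2 in this assay, since all these results are limits and not numbers, and the series rests on one shared limit: the limit of > 500000 nM in this assay, at which 4 of the 4 values shown sit.

The compounds shown leave open whether bromo in place of fluoro, or the six-membered ring in place of the five-membered ring, changes the result in this assay at all.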